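The compounds below may be only part of what the source reports. "The series", "measured", "known", "first", "only" and "open" are said of these compounds alone.

Three close relatives built on one shared core have been tested in a functional assay on 4T1 cells (Mus musculus) for cytotoxicity, read by MTT assay, with a stated time of 24 h; on this read-out higher numbers stand for weaker inhibition and lower numbers for stronger inhibition. Compound 1 `Cc1ccc(/C=C2\CN(C(=S)SCc3cn(Cc4ccccc4Cl)nn3)C/C(=C\c3ccc(C)cc3)C2=O)cc1` gives 49300 nM in this assay. Compound 3 `O=C1/C(=C/c2ccccc2F)CN(C(=S)SCc2cn(Cc3ccccc3F)nn2)C/C1=C\c1ccccc1F` gives 30700 nM in this assay, which lies within the scatter of the number for compound 1, so the two cannot be ranked. Compound 2 `COc1ccc(/C=C2\CN(C(=S)SCc3cn(Cc4ccc(F)cc4)nn3)C/C(=C\c3ccc(OC)cc3)C2=O)cc1` reaches only a limit of this assay, > 100000 nM, so no number is known for it (the limit of > 100000 nM in this assay, at which 1 of the 3 values shown sits). Compound 4 `Cc1ccc(/C=C2\CN(C(=S)SCc3cn(Cc4ccc(F)cc4)nn3)C/C(=C\c3ccc(C)cc3)C2=O)cc1` is not yet measured; it differs from compound 1 in one place: 4-fluorophenyl in place of 2-chlorophenyl on a saturated chain carbon bound to an aromatic nitrogen. Among the compounds with values here, no measured pair shows this change on its own, so its size is open; with inhibition this weak throughout, little shift beyond the scatter is expected. Compound 4 is therefore estimated to give 70000 nM in this assay, between 30000 nM and 150000 nM. The expected step is a 1.4-fold higher number from compound 1 to compound 4 (0.15 log units; within the scatter).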

Compound 4, half-maximal inhibitory concentration: 29300 nM
Estimate against measurement, compound 4: 2.4-fold (0.38 log units) above; measured number outside the range, below it.
By their numbers in this assay, from the lowest: compounds 4, 3 and 1 (each within the scatter of the next). At a limit, above all of these: compound 2.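

Within the data shown here, this is the first pair in which only one group changes: 4-fluorophenyl in place of 2-chlorophenyl, on a saturated chain carbon bound to an aromatic nitrogen, gives a 1.7-fold lower number from compound 1 to compound 4 (0.23 log units; within the scatter) in this assay. Compounds 1 and 4 therefore cannot be ranked, and this exchange of one substituted phenyl for the other leaves no readable mark on the result. Nothing shown here gives a cause for this step.

Still open, as far as these compounds go, is whether a different group at this place, such as a carboxylic acid or an amine on a longer chain, would shift the number beyond the scatter.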